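The compounds below may be only part of what the source reports. "The series", "measured", "known", "first", "only" and "open" are said of these compounds alone.

Measured compounds:
Compound 1 `Clc1ccc(-c2cn3nc(Cl)sc3n2)cc1` gives 95000 nM in a functional assay on HeLa cells (Homo sapiens) for cytotoxicity, with a stated time of 72 h; on this read-out higher numbers stand for weaker inhibition and lower numbers for stronger inhibition.
Compound 2 `O=[N+]([O-])c1ccc(-c2cn3nc(Cc4ccc(Cl)cc4)sc3n2)cc1` gives only a limit in this assay, > 250000 nM.

On the numbers shown, compound 2 stands at the limit of this assay, (the limit of > 250000 nM in this assay, at which 1 of the 2 values shown sits), so no number is known for it and its distance from compound 1 cannot be sized. Compound 3 `O=[N+]([O-])c1ccc(-c2nc3sc(Cc4ccc(Cl)cc4)nn3c2Br)cc1` differs from compound 2 by bromo in place of hydrogen on an aromatic carbon. Among the measured compounds shown here, no measured pair shows this change, so there is no step to lean on. The step from compound 2 to compound 3 is expected to be an at least 1.2-fold lower number from compound 2 to compound 3 (0.09 log units; that floor lies within the scatter), none beyond the usual scatter. Compound 3 is therefore expected near 200000 nM, between 60000 nM and 600000 nM, with a real chance that this assay again reports only a limit rather than a number.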

Compound 3, half-maximal inhibitory concentration: > 250000 nM
Compound 3: no number, only a limit (the forecaster's own chance of this, stated with the estimate: 55%); at least 1.2-fold (0.09 log units) between middle value and limit.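

Compound 2 and compound 3 both give only a limit in this assay, so no step can be read between them: the limit of > 250000 nM in this assay, at which 2 of the 3 values shown sit.

The compounds shown leave open how far, if at all, bromo in place of hydrogen on an aromatic carbon shifts the half-maximal inhibitory concentration.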